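This account rests on a few compounds, and the source may have more. Where it says the series, first, only, none or still open, it means among the compounds named here.

Measured compounds:
- compound 1 `C=C1C(=O)O[C@H]2C[C@H](C)[C@@]34C[C@@H](C[C@@]35C(=O)O[C@@H]3C[C@@]6(C)[C@@H](O)C[C@@H](O)C(=C)[C@@H]6C[C@@H]35)C(C)=C4C[C@H]12` — 140 nM
- compound 2 `C=C1C(=O)O[C@H]2C[C@H](C)C3=C(C[C@H]12)[C@@]1(C)C[C@H]3C[C@@]12C(=O)O[C@@H]1C[C@@]3(C)[C@@H](O)C[C@@H](O)C(=C)[C@@H]3C[C@@H]12` — 140 nM
- compound 3 `C=C1C(=O)O[C@H]2C[C@H](C)C3=C(C[C@H]12)[C@@]1(C)C[C@@H]3C[C@@]12C(=O)O[C@H]1C=C(C)[C@H]3CC[C@@](C)(O)[C@@H]3C[C@@H]12` — 2030 nM

In a functional assay on CCRF-CEM cells (Homo sapiens) for cytotoxicity (on this read-out higher numbers stand for weaker inhibition and lower numbers for stronger inhibition), compound 2 gives 140 nM and compound 1 gives 140 nM; the two numbers agree at the digits shown, within the scatter, and together they are the lowest of the three. Furthest from compound 2 stands compound 3, which gives 2030 nM, a markedly higher number, well beyond the scatter. Compound 2 is therefore one of the two lowest numbers in this set.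

Compound 4 `C=C1C(=O)O[C@H]2C[C@@H](C)C3=C(C[C@H]12)[C@@]1(C)C[C@@H]3C[C@@]12C(=O)O[C@@H]1C[C@@]3(C)[C@@H](O)C[C@@H](O)C(=C)[C@@H]3C[C@@H]12` has not yet been measured. Its relation to compound 2 is a change of configuration alone: the two compounds have the same atoms and bonds and differ only in configuration as drawn: 2 of 12 stereo elements differ; a stereocentre at a saturated ring carbon is drawn S in compound 2 and R in compound 4; a stereocentre at a saturated ring carbon is drawn S in compound 2 and R in compound 4. For the measured compounds named here, no step between measured compounds isolates such a change, so the size of its effect is not known from these data. Compound 1 and compound 2, which are drawn as different stereoisomers of the same skeleton, show the same number in this assay, which suggests that configuration alone need not move the read-out far. Compound 4 is expected to give 250 nM, within 80 nM to 900 nM, a step from compound 2 to compound 4 estimated as a 1.8-fold higher number from compound 2 to compound 4 (0.25 log units; within the scatter), close to or only slightly beyond the scatter.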

Compound 4, half-maximal inhibitory concentration: 140 nM
For compound 4 the middle estimate is 1.8-fold (0.25 log units) above the measured one; the measured number falls inside the stated range.
By their numbers in this assay, from the lowest: compounds 1, 2 and 4 (each within the scatter of the next); then compound 3.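

In this assay, the set now has a step that isolates configuration, and it reads no change at the digits printed from compound 2 to compound 4 (within the scatter). Two stereocentres at saturated ring carbons, drawn S in compound 2 and R in compound 4, can therefore be inverted together without moving this read-out beyond the scatter. This reading can be assigned to configuration alone, because no atom or bond separates the pair: the fact that compounds 2 and 4 differ only in the configuration as drawn.

Since both centres change in the same step, the contribution of each one alone cannot be read, and a single inversion could behave differently. From the compounds shown here alone, whether the read-out would hold if an amine replaced a hydroxyl group on the shared core also remains open.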